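The compounds below may be only part of what the source reports. "The series", "measured", "known", "first", "only" and "open" are said of these compounds alone.

Compound 3 `CCN(CC)CCNc1nc(-c2ccc(NC(=O)Nc3ccc(F)cc3)cc2)nc2c(Cl)c(Cl)sc12` sits second highest of the three numbers in a functional assay on MDA-MB-231 cells (Homo sapiens) for cytotoxicity, read by MTT assay, with a stated time of 72 h; on this read-out lower numbers stand for stronger inhibition and higher numbers for weaker inhibition: compound 3 gives 1130 nM, compound 1 `CN(C)CCCNc1nc(-c2ccc(NC(=O)Nc3ccc(Cl)cc3)cc2)nc2c(Cl)c(Cl)sc12` gives 1160 nM and compound 2 `CN(C)CCNc1nc(-c2ccc(NC(=O)Nc3ccc(Cl)cc3)cc2)nc2c(Cl)c(Cl)sc12` gives 870 nM, all three within the scatter of one another. Among the compounds with values here, the only single-point step among the measured compounds, a 1.3-fold lower number from compound 1 to compound 2 (0.12 log units; within the scatter), concerns the amine chain and not the halogen on the urea phenyl. Compound 4 `CCN(CC)CCNc1nc(-c2ccc(NC(=O)Nc3ccc(Cl)cc3)cc2)nc2c(Cl)c(Cl)sc12` differs from compound 3 by chloro in place of fluoro on an aromatic carbon. Within the data shown here, no measured step covers this exchange, and the three numbers so far give no sign that it matters; the step in this assay is therefore expected to stay within the scatter, in no particular direction. For compound 4 in this assay the estimate is 1100 nM, range 500 nM to 2500 nM, meaning an expected step of a 1.0-fold lower number from compound 3 to compound 4 (0.01 log units; within the scatter).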

Compound 4, half-maximal inhibitory concentration: 750 nM
For compound 4 the middle estimate is 1.5-fold (0.17 log units) above the measured one; the range from low to high includes it.
By their numbers in this assay, from the lowest: compounds 4, 2, 3 and 1 (each within the scatter of the next).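

Within the data shown here, in (this assay), the first reading of chloro in place of fluoro on an aromatic carbon, para to a large group (a 1.5-fold lower number from compound 3 to compound 4 (0.18 log units; within the scatter)), shows that this exchange is tolerated within the scatter. With chloro held on that ring, the amine end also stays within the scatter, for diethylamino in place of dimethylamino (a 1.2-fold lower number from compound 2 to compound 4 (0.06 log units; within the scatter)) and for diethylamino in place of (dimethylamino)methyl (a 1.5-fold lower number from compound 1 to compound 4 (0.19 log units; within the scatter)). Nothing available bears on what lies behind these small steps.

Open, from the compounds shown here alone, is whether methoxy or trifluoromethyl on that ring carbon would hold the number in this range. Also open, going by these compounds, is how a morpholine or pyrrolidine at the chain end would read.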